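This account rests on a few compounds, and the source may have more. Where it says the series, first, only, none or still open, it means among the compounds named here.

Compound 1 `Cc1cc(-c2ccc(F)cc2)nnc1N1CCN(c2ncccn2)CC1` gives 76300 nM in a functional assay on BV-2 cells (Mus musculus) for inhibition, read by ELISA, with a stated time of 16 h; on this read-out higher numbers stand for weaker inhibition and lower numbers for stronger inhibition.
Compound 2 `Cc1ccc(-c2cc(C)c(N3CCN(c4ncccn4)CC3)nn2)cc1` gives 17200 nM in this assay.
Compound 3 `COc1ncc(-c2cc(C)c(N3CCN(c4ncccn4)CC3)nn2)c(OC)n1` gives only a limit in this assay, > 100000 nM.

Compound 2 holds the lowest of the two numbers; its nearest neighbour is compound 1, with a 4.4-fold lower number from compound 1 to compound 2 (0.65 log units; beyond the scatter). Compound 3 sits at the limit of > 100000 nM in this assay, at which 1 of the 3 values shown sits.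

Compound 4 `Cc1cc(-c2ccc3[nH]ccc3c2)nnc1N1CCN(c2ncccn2)CC1` differs from compound 2 by 1H-indol-5-yl in place of 4-methylphenyl on an aromatic carbon. Among the measured compounds shown here, the one measured step, a 4.4-fold lower number from compound 1 to compound 2 (0.65 log units; beyond the scatter), exchanges one small substituent for another and does not involve a fused ring or a hydrogen-bond donor, so it bears only loosely on this change. The limit of compound 3 shows that a different aromatic group in this position can push the number out of range. Compound 4 is therefore expected to give a somewhat higher number, a 2.0-fold higher number from compound 2 to compound 4 (0.31 log units; beyond the scatter), with wide uncertainty. Compound 4 is estimated at 35000 nM, between 8000 nM and 100000 nM.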

Compound 4, half-maximal inhibitory concentration: 85100 nM
Estimate against measurement, compound 4: 2.4-fold (0.39 log units) below; the range from low to high includes it.
By their numbers in this assay, from the lowest: compound 2; then compounds 1 and 4 (each within the scatter of the next). At a limit, above all of these: compound 3.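

Set against 4-methylphenyl, the 1H-indol-5-yl group at this aromatic carbon gives a 4.9-fold higher number from compound 2 to compound 4 (0.69 log units; beyond the scatter) in this assay, so among the measured groups the lower number belongs to compound 2 alone. Set against 4-fluorophenyl, it gives a 1.1-fold higher number from compound 1 to compound 4 (0.05 log units; within the scatter), which places the larger group with its hydrogen-bond donor level with the fluoro compound. Compound 3 remains the only compound at a limit: the limit of > 100000 nM in this assay, at which 1 of the 4 values shown sits.

As far as these compounds go, whether an amine or a carboxylic acid on the aromatic group, or a longer chain in place of the methyl of 4-methylphenyl, would give a number lower than that of compound 2 stays open.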